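Fluoro for Bromo on the Aryl Amine of a Urea Series

The compounds below may be only part of what the source reports. "The series", "measured", "known", "first", "only" and "open" are said of these compounds alone.

Compound 2 `COc1cc(NC(=O)Nc2cc(Nc3cc(Br)ccc3OC)ncn2)cc(OC)c1` gives 43.5% in a functional assay on NCI-H520 cells (Homo sapiens) for inhibition, read by MTT assay, with a stated time of 48 h, tested at 10 uM; a higher number here means more inhibition at the concentration tested (going by the name of the read-out), a lower number less inhibition. On the numbers shown it stands second of three: compound 1 `COc1ccc(Br)cc1Nc1cc(NC(=O)Nc2c(Cl)cccc2Cl)ncn1` gives 45%, and a number 1.5 percentage points lower from compound 1 to compound 2 (within the scatter); compound 3 `CCc1ccc(Nc2cc(NC(=O)Nc3c(Cl)cccc3Cl)ncn2)cc1` gives 31.5%, and a number 13.5 percentage points lower from compound 1 to compound 3 (beyond the scatter). Compound 4 `COc1cc(NC(=O)Nc2cc(Nc3cc(F)ccc3OC)ncn2)cc(OC)c1` differs from compound 2 by fluoro in place of bromo on an aromatic carbon. Going by the values given here, no measured step exchanges one halogen for another at this place; the nearest guide is the replacement of the whole 5-bromo-2-methoxyphenyl group seen in compound 3, which is a far larger change. A single fluoro in place of bromo on an aromatic carbon is expected to move this assay little, if at all, so the step of a number 5.5 percentage points lower from compound 2 to compound 4 (within the scatter) is expected to stay within the scatter, leaning slightly downward. Compound 4 is therefore estimated at 38%, between 25% and 52%.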

Compound 4, a percentage reported as inhibition, at one concentration (the size of the read-out at that concentration, not a potency): 38%
Estimate against measurement, compound 4: no gap at the digits printed; low and high end bracket the measured number.
By their numbers in this assay, from the lowest: compounds 3, 4, 2 and 1 (each within the scatter of the next, the first and the last beyond it).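

In this assay, exchanging only the halogen para to a methoxy group gives a number 5.5 percentage points lower from compound 2 to compound 4 (within the scatter), a reading of this place alone, where compound 3 had replaced the whole 5-bromo-2-methoxyphenyl group. With the 3,5-dimethoxyphenyl group in place, bromo is therefore not needed to keep the reading within the scatter. Nothing available explains this result. From the compounds shown here alone, whether chloro, methyl or an amine at this place would read the same stays open. So does whether the exchange holds with the 2,6-dichlorophenyl group of compound 1.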